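The source may hold more compounds than are shown below. What is called first, only, known or untested is meant among the compounds shown, and "the series" means these compounds.

Compound 1 `CCN1CCN(c2ccc(S(=O)(=O)Oc3cccc(F)c3)cc2)C1=O` is one of three measured compounds. In a functional assay on MCF7 cells (Homo sapiens) for antiproliferative activity, read by sulforhodamine B assay, with a stated time of 48 h (a lower number here means a stronger inhibitor, a higher number a weaker inhibitor), compound 1 gives > 100000 nM, which is a limit of the assay rather than a number. Compound 2 `CCN1CCN(c2ccc(S(=O)(=O)Oc3cccc(Br)c3)cc2)C1=O` gives 2500 nM in this assay. Compound 3 `CCCCN1CCN(c2ccc(S(=O)(=O)Oc3cccc(F)c3)cc2)C1=O` gives 310 nM in this assay.

Compound 2 differs from compound 1 in one place: bromo in place of fluoro on an aromatic carbon. That change brought a large step, an at least 40-fold lower number from compound 1 to compound 2 (1.60 log units; beyond the scatter), though since compound 1 sits at the limit of > 100000 nM in this assay, at which 1 of the 3 values shown sits, the true size of the step is not known, only that it is at least this large. Compound 3 differs from compound 1 elsewhere, by ethyl in place of hydrogen on a saturated chain carbon, two bonds along the chain from an amide-type nitrogen in a ring, and that change brought an at least 320-fold lower number from compound 1 to compound 3 (2.50 log units; beyond the scatter), again counted from a limit. Among the measured compounds, compound 3 stands lowest in this assay, with compound 2 nearest.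

Compound 4 `CCCCN1CCN(c2ccc(S(=O)(=O)Oc3cccc(Br)c3)cc2)C1=O` has not been measured. It differs from compound 3 by bromo in place of fluoro on an aromatic carbon, which is the same change that separates compound 1 from compound 2, made at the same place. If the change works as it did before, compound 4 is expected to sit below compound 3 by about a 3.9-fold lower number from compound 3 to compound 4 (0.59 log units; beyond the scatter), a step that is estimated more cautiously than the earlier one, since the earlier one is known only as a minimum and compound 3 already gives a low number. Compound 4 is therefore estimated at 80 nM in this assay, somewhere between 20 nM and 300 nM.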

Compound 4, half-maximal inhibitory concentration: 85 nM
The estimate for compound 4 lay 1.1-fold (0.03 log units) below the measured number; the range from low to high includes it.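

Bromo in place of fluoro lowers the number again in this assay, with a 3.6-fold lower number from compound 3 to compound 4 (0.56 log units; beyond the scatter), so the direction of the change carries from the core of compound 1 to the core of compound 3, but its size does not: the same change on two cores in this assay, an at least 40-fold lower number (1.60 log units; beyond the scatter) from compound 1 to compound 2 and a 3.6-fold lower number (0.56 log units; beyond the scatter) from compound 3 to compound 4, at least 10-fold (1.04 log units) apart, beyond the scatter of two such steps. The other change behaves the same way, since ethyl in place of hydrogen on the chain gives a 29-fold lower number from compound 2 to compound 4 (1.47 log units; beyond the scatter), again in the same direction as before but with a different size: the same change on two cores in this assay, an at least 320-fold lower number (2.50 log units; beyond the scatter) from compound 1 to compound 3 and a 29-fold lower number (1.47 log units; beyond the scatter) from compound 2 to compound 4, at least 10-fold (1.04 log units) apart, beyond the scatter of two such steps. Within the data shown here, both of the earlier steps start from compound 1, whose value is a limit and not a number, so their true size stays unknown, and a comparison of only two cores gives neither a reason for the gap nor a rule for a third core: the limit of > 100000 nM in this assay, at which 1 of the 4 values shown sits.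

From the compounds shown here alone, it remains open what chloro or iodo would do at this place on the ring, and whether a still longer chain, such as hexyl, would lower the number further or raise it again. Going by these compounds, it is also open how an amine or a carboxylic acid at the end of that chain would change the result, and whether bromo would still lower the number on such a core.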